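Cyclopropyl to 4-methoxyphenyl on the ring amide nitrogen

This account rests on a few compounds, and the source may have more. Where it says the series, first, only, none or still open, it means among the compounds named here.

Of the compounds shown here, two on a shared core have been read in a functional assay on A-375 cells (Homo sapiens) for antiproliferative activity, read by MTT assay, with a stated time of 72 h; a higher number here means a weaker inhibitor, a lower number a stronger inhibitor. Compound 1 `O=C1COc2ccc(-c3cccc(NS(=O)(=O)c4ccc(F)cc4)c3)cc2N1c1ccc(Cl)cc1`, with 4-chlorophenyl on the amide-type nitrogen in a ring, gives 32500 nM. Compound 2 `O=C1COc2ccc(-c3cccc(NS(=O)(=O)c4ccc(F)cc4)c3)cc2N1C1CC1`, with cyclopropyl at that place, reads > 40000 nM, which is a limit of the assay and not a number. Compound 2 therefore has no exact standing in the series, and the data at the ceiling are plain: the limit of > 40000 nM in this assay, at which 1 of the 2 values shown sits.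

The next compound is compound 3 `COc1ccc(N2C(=O)COc3ccc(-c4cccc(NS(=O)(=O)c5ccc(F)cc5)c4)cc32)cc1`, with 4-methoxyphenyl in place of cyclopropyl on an amide-type nitrogen in a ring. Going by the values given here, the one measured step bearing on this change is an at least 1.2-fold higher number from compound 1 to compound 2 (0.09 log units; that floor lies within the scatter). It exchanges the same cyclopropyl for a group that also holds a six-membered aromatic ring of carbon only, but its size is known only as a floor. Compound 3 is therefore expected to read near compound 1 at 32500 nM, perhaps with a modest move towards a lower number and nothing firmly beyond the scatter.

For compound 3 the estimate is 30000 nM, with an expected range of 13000 nM to 60000 nM. The estimated step is an at least 1.3-fold lower number from compound 2 to compound 3 (0.12 log units; that floor lies within the scatter), and a reading at the limit remains possible.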

Compound 3, half-maximal inhibitory concentration: 38500 nM
Beside the measured number, compound 3's estimate is 1.3-fold (0.11 log units) below it; low and high end bracket the measured number.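

In this assay, methoxy in place of chloro on an aromatic carbon gives a 1.2-fold higher number from compound 1 to compound 3 (0.07 log units; within the scatter), so 4-methoxyphenyl and 4-chlorophenyl on the amide-type nitrogen in a ring cannot be told apart in this series. Against cyclopropyl, the change gives an at least 1.0-fold lower number from compound 2 to compound 3 (0.01 log units; that floor lies within the scatter), and this floor gives no ranking of 4-methoxyphenyl relative to cyclopropyl at this place. Compound 2 remains a limit of the assay and not a number, so its distance from the other two compounds cannot be stated: the limit of > 40000 nM in this assay, at which 1 of the 3 values shown sits.

Still open is whether a carboxylic acid, an amine or a longer alkyl chain on this nitrogen would give a lower number beyond the scatter, since the three groups shown do not separate from one another on the available readings. Also open, on these data alone, is whether changes elsewhere on the shared core would move the reading further than any change at this nitrogen.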